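This account rests on a few compounds, and the source may have more. Where it says the series, first, only, none or still open, it means among the compounds named here.

Measured so far:
compound 1 `CC(=O)N1CCC(c2cc3c(-c4ccc(=O)n(C(C)C)c4)ccnc3[nH]2)CC1` — 2.8 uL/min
compound 2 `COc1cc(C(=O)N2CCCC2)ccc1-c1ccnc2[nH]c(C3CCOCC3)cc12` — 15 uL/min
compound 3 `CN(C)C(=O)CN1CCC(c2cc3c(-c4ccc(=O)n(C5CCOCC5)c4)ccnc3[nH]2)CC1` — 2.3 uL/min

In an ADME assay on cells (Hepatocyte, Rattus norvegicus) for metabolic stability (on this read-out lower numbers stand for slow clearance and higher numbers for fast clearance), compound 3 gives the lowest of the three numbers. Compound 1 sits nearest, within the usual scatter of repeated measurements, so the two cannot be ordered; compound 2 is the furthest, with a gap beyond the scatter. Compound 4 `CN(C)C(=O)CN1CCC(c2cc3c(-c4ccc(=O)n(C5CCC5)c4)ccnc3[nH]2)CC1` has not yet been measured. It differs from compound 3 in one place: cyclobutyl in place of oxan-4-yl on an aromatic nitrogen. Going by the values given here, no step between measured compounds covers this change, so there is no measured reference for it. The step of a 1.7-fold higher number from compound 3 to compound 4 (0.24 log units; within the scatter) is expected to be small and upward, not clearly beyond the scatter. Compound 4 is estimated at 4 uL/min, with a range from 1.5 uL/min to 10 uL/min.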

Compound 4, intrinsic clearance in a liver preparation (reported as CLH), per the amount of preparation that the assay uses: 5.8 uL/min
Compound 4: the middle estimate sits 1.5-fold (0.16 log units) below what was measured, and the stated range covers the measured number.
By their numbers in this assay, from the lowest: compounds 3 and 1 (each within the scatter of the next); then compound 4; then compound 2.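

In this assay, going by these compounds alone, cyclobutyl in place of oxan-4-yl on an aromatic nitrogen gives a 2.5-fold higher number from compound 3 to compound 4 (0.40 log units; beyond the scatter) and so shows that the group at this position can move clearance, which the earlier compounds could not show in a single change. The direction here is upward on leaving the oxygen-bearing six-membered ring for the four-membered carbon ring. No measurement at hand accounts for the step.

This one step does not separate ring size from the ring oxygen. Going by these compounds, a cyclohexyl or an oxetan-3-yl group on this nitrogen would address that, and both remain open.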